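A Fluorophenoxy Tail in Place of a Methylpiperazinyl Group

A few compounds are considered here, and "the series" means these few. Any claim that something is new, unique, unknown or untested is made for them only; others in the source may bear on it.

Compound 1, `COc1ccc(-c2cc(=O)c3c(OC)cc(OC)cc3[nH]2)cc1`, in a functional assay on KOPN-8 cells (Homo sapiens) for antiproliferative activity, with a stated time of 72 h (a higher number here means that more compound is needed for the effect, a lower number that less compound is needed), reaches only a limit of > 31100 nM.
Compound 2, `COc1cc(OC)c2c(=O)cc(C(=O)Nc3ccc(C4CCCCC4)cc3)[nH]c2c1`, gives 18400 nM.
Compound 3, `COc1cc(OC)c2c(=O)cc(C(=O)Nc3ccc(N4CCN(C)CC4)cc3)[nH]c2c1`, gives only a limit of > 19800 nM.

Compound 3 therefore stands at a limit, (the limit of > 19800 nM in this assay, at which 1 of the 3 values shown sits), and compound 1 at another, (the limit of > 31100 nM in this assay, at which 1 of the 3 values shown sits). For the measured compounds named here, the one measured step touching this position, an at least 1.0-fold higher number from compound 2 to compound 3 (0.03 log units; that floor lies within the scatter), is itself bounded by that limit. The unmeasured compound 4, `COc1cc(OC)c2c(=O)cc(C(=O)Nc3ccc(Oc4ccc(F)cc4)cc3)[nH]c2c1`, carries the change (4-fluorophenoxy in place of 4-methylpiperazin-1-yl on an aromatic carbon). Going by the values given here, no measured step covers a phenoxy group, so the expectation leans on compound 2 as the only numerical value nearby. Compound 4 is expected to come out near 15000 nM, between 4000 nM and 40000 nM, which would mean an estimated step of an at least 1.3-fold lower number from compound 3 to compound 4 (0.12 log units; that floor lies within the scatter).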

Compound 4, half-maximal effective concentration: > 50000 nM
Compound 4 ended at the assay's limit (the forecaster's own chance of this, stated with the estimate: 35%); at least 3.3-fold (0.52 log units) between middle value and limit.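

In this assay, this position now shows a step beyond the scatter: 4-fluorophenoxy in place of cyclohexyl gives an at least 2.7-fold higher number from compound 2 to compound 4 (0.43 log units; beyond the scatter). Compound 4 reaches only a limit, > 50000 nM. The step between compound 3 and compound 4 cannot be read, as both values are limits.

Compound 2 remains the only one of these amides with a true number, so it is still unclear what would lower that number. Also open, going by these compounds, is whether a primary amine or a carboxylic acid on that aromatic carbon would give a readable value.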